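Swapping methyl for cyano on a fused aromatic core

This account rests on a few compounds, and the source may have more. Where it says the series, first, only, none or still open, it means among the compounds named here.

The shared core carries a pyrimidinedione chain linked through an ether to a fused two-ring aromatic system, and the question is how a small change on that system affects toxicity toward cells. Among the measured compounds shown here, in an ADME assay on MT2 cells (Homo sapiens) for cytotoxicity, read by MTT assay (on this read-out lower numbers stand for higher toxicity in this test and higher numbers for lower toxicity in this test), compound 1, `Cc1ccc2c(Oc3ccccc3OCCn3ccc(=O)[nH]c3=O)cccc2c1`, gives 40000 nM, the only full number so far. Compound 2, `N#Cc1cc2c(Oc3ccccc3OCCn3ccc(=O)[nH]c3=O)cccc2o1`, gives only a limit of the test, > 100000 nM, in this assay. The change to compound 3, `N#Cc1ccc2c(Oc3ccccc3OCCn3ccc(=O)[nH]c3=O)cccc2c1`, is cyano in place of methyl on an aromatic carbon. For the measured compounds named here, no measured pair differs in just one place, so the size of this step has no direct precedent. In this assay the step from compound 1 to compound 3 is expected to be modest, toward lower toxicity, likely near the edge of the usual scatter, a 1.6-fold higher number from compound 1 to compound 3 (0.21 log units; within the scatter). Compound 3 is therefore estimated at 65000 nM, with a range from 25000 nM to 100000 nM, and there is a fair chance that the test again reports only a limit rather than a number.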

Compound 3, half-maximal cytotoxic concentration: > 100000 nM
Compound 3 was reported as a limit (the forecaster's own chance of this, stated with the estimate: 35%); at least 1.5-fold (0.18 log units) between middle value and limit.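

Compound 3 gives > 100000 nM in this assay, which is a limit of the test and not a full number. Even so, this is the first comparison here between two compounds that differ in only one place, and cyano in place of methyl on this aromatic carbon gives an at least 2.5-fold higher number from compound 1 to compound 3 (0.39 log units; beyond the scatter), so the change moves toward lower toxicity in this test, and the step lies beyond the usual scatter. Only the minimum size of this step can be read, and its true size remains unknown because the values stop at the top of the test's range: the limit of > 100000 nM in this assay, at which 2 of the 3 values shown sit.

The compounds shown leave open whether the higher number depends on cyano itself or would also appear with another small group in place of methyl, such as a plain hydrogen, an amine or a carboxylic acid on the same aromatic carbon. They also leave open how far compound 3 lies beyond the limit, which a full number would be needed to settle.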